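Fluorine on the Central Ring of a Weak Cytotoxic Series

The source may hold more compounds than are shown below. What is called first, only, known or untested is meant among the compounds shown, and "the series" means these compounds.

Measured compounds:
Compound 1, `Cn1ccc2c(Oc3ccc(NC(=O)c4nn(-c5ccc(Cl)cc5)ccc4=O)cc3)ccnc21`: > 60000 nM
Compound 2, `Cn1ccc2c(Oc3ccc(NC(=O)c4nn(-c5ccccc5)ccc4=O)cc3)ccnc21`: 51700 nM
Compound 3, `Cn1ccc2c(Oc3ccc(NC(=O)c4nn(-c5ccc(Cl)c(F)c5)ccc4=O)cc3)ccnc21`: > 60000 nM

In a functional assay on A549 cells (Homo sapiens) for cytotoxicity, read by MTT assay, with a stated time of 72 h (a lower number here means a stronger inhibitor, a higher number a weaker inhibitor), only compound 2 gives a number, 51700 nM. Compound 1 reaches only a limit of the assay, > 60000 nM. Compound 3 likewise reaches only a limit, > 60000 nM. Among the compounds with values here, this is the limit of > 60000 nM in this assay, at which 2 of the 3 values shown sit, so compound 2 stands as the single measured value among three, and the whole set is weakly active.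

Compound 4, `Cn1ccc2c(Oc3ccc(NC(=O)c4nn(-c5ccccc5)ccc4=O)cc3F)ccnc21`, differs from compound 2 by fluoro in place of hydrogen on an aromatic carbon. Within the data shown here, none of the measured steps touches the same ring. The step of an at least 1.1-fold lower number from compound 1 to compound 2 (0.06 log units; that floor lies within the scatter) removes a chloro from the ring on the aromatic nitrogen; the step of an at least 1.1-fold higher number from compound 2 to compound 3 (0.06 log units; that floor lies within the scatter) adds chloro and fluoro to that same ring; the step that the two limits leave unreadable from compound 1 to compound 3 cannot be read because of the limits. All three speak only to the ring on the nitrogen, and none exceeds the scatter. For compound 4 no step beyond the scatter is therefore expected in this assay, in either direction. Compound 4 is estimated to give 52000 nM, with a range from 25000 nM to 100000 nM, which corresponds to an expected step of a 1.0-fold higher number from compound 2 to compound 4 (0.00 log units; within the scatter).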

Compound 4, half-maximal inhibitory concentration: > 60000 nM
Compound 4: a limit, no number (the forecaster's own chance of this, stated with the estimate: 45%); middle value at least 1.1-fold (0.06 log units) from the limit.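

Within the data shown here, this is the first change on the six-membered aromatic ring of carbon only, the ring that carries a large group on each side of the new fluoro, since the earlier steps all concerned the ring on the nitrogen. In this assay compound 4 gives > 60000 nM as a limit of the assay and not a number. Read against the one measured compound of the series, the change gives an at least 1.1-fold higher number from compound 2 to compound 4 (0.06 log units; that floor lies within the scatter) and so shows only that a single fluoro in this place, ortho to one large group and meta to another, does not bring the value down to a readable number, and the loss of a number cannot be taken as a real weakening, since the floor of the step stays within the scatter; compound 2 is now the only compound with a number, and most of the series sits at one ceiling: the limit of > 60000 nM in this assay, at which 3 of the 4 values shown sit.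

From the compounds shown here alone, what number compound 4 would give in a wider test range stays open. Also open, going by these compounds, is whether a methyl group, an amine or a carboxylic acid on this same carbon would give a number clearly different from that of compound 2.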